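A Hydroxyl Replaces Fluorine on the Aryl Imine

This account rests on a few compounds, and the source may have more. Where it says the series, first, only, none or still open, it means among the compounds named here.

Compound 2 `CCCCc1oc2ccc(/N=C/c3ccc(F)cc3)cc2c1C(=O)c1ccc(OC)cc1` gives the highest number of the three measured in a functional assay, with a stated time of 30 min (on this read-out higher numbers stand for weaker inhibition and lower numbers for stronger inhibition), at 100 ug/mL. Compound 1 `CCCCc1oc2ccc(/N=C/c3ccc(O)cc3)cc2c1C(=O)c1ccc(OC)cc1` gives 22.8 ug/mL and compound 3 `CCCCc1oc2ccc(/N=C/c3ccc(O)cc3O)cc2c1C(=O)c1ccc(OC)cc1` gives 7.55 ug/mL, both beyond the scatter from compound 2. Compound 4 `CCCCc1oc2ccc(/N=C/c3ccccc3O)cc2c1C(=O)c1ccc(OC)cc1` carries 2-hydroxyphenyl in place of 4-fluorophenyl on a carbon with a double bond to nitrogen. Among the compounds with values here, three measured steps bear on this change: a 4.4-fold higher number from compound 1 to compound 2 (0.64 log units; beyond the scatter), a 3.0-fold lower number from compound 1 to compound 3 (0.48 log units; beyond the scatter) and a 13-fold lower number from compound 2 to compound 3 (1.12 log units; beyond the scatter). Within the data shown here, in every one of these a hydroxy on that ring went with a lower number, with no compound going against it. Compound 4, carrying a single hydroxy, is therefore expected to show a 4.0-fold lower number from compound 2 to compound 4 (0.60 log units; beyond the scatter). Compound 4 is estimated at 25 ug/mL in this assay, within a range from 8 ug/mL to 70 ug/mL.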

Compound 4, half-maximal inhibitory concentration: 99.4 ug/mL
Compound 4: middle estimate off by 4.0-fold (0.60 log units), on the low side; measured number above the stated range.
By their numbers in this assay, from the lowest: compound 3; then compound 1; then compounds 4 and 2 (each within the scatter of the next).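

In this assay, 2-hydroxyphenyl and 4-fluorophenyl on this carbon cannot be told apart (a 1.0-fold lower number from compound 2 to compound 4 (0.00 log units; within the scatter)), so a hydroxy on this ring does not go with a lower number in every compound. Its place on the ring matters: 2-hydroxyphenyl in place of 4-hydroxyphenyl gives a 4.4-fold higher number from compound 1 to compound 4 (0.64 log units; beyond the scatter), and removing one hydroxy from the 2,4-dihydroxyphenyl ring of compound 3 gives a 13-fold higher number from compound 3 to compound 4 (1.12 log units; beyond the scatter). No evidence is given that explains this difference.

The compounds shown leave open how an amine or a carboxylic acid would behave on this ring, in place of the hydroxy of 4-hydroxyphenyl or of 2-hydroxyphenyl.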